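A few compounds are considered here, and "the series" means these few. Any claim that something is new, unique, unknown or untested is made for them only; others in the source may bear on it.

In a functional assay, read by spectrophotometry, with a stated time of 3 min (a lower number here means a stronger inhibitor, a higher number a weaker inhibitor), compound 2 `O=c1[nH]c2ccccc2cc1/C=N/c1ccc(O)cc1` gives 7150 nM. Compound 1 `Cc1ccc2[nH]c(=O)c(/C=N/c3ccc(O)cc3)cc2c1` gives 5240 nM and compound 3 `NS(=O)(=O)CC(=O)N/N=C/c1cc2ccccc2[nH]c1=O` gives 8910 nM. All three numbers lie within the usual scatter of one another, so no real order can be drawn among them.

Compound 4 `NS(=O)(=O)c1ccc(/N=C/c2cc3ccccc3[nH]c2=O)cc1` has sulfamoyl in place of hydroxy on an aromatic carbon of compound 2, para to a large group: sulfamoyl in place of hydroxy on an aromatic carbon.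

Going by the values given here, only one measured step offers any guide, a 1.4-fold higher number from compound 1 to compound 2 (0.13 log units; within the scatter). It lies within the scatter, but it exchanges different groups at a different place, so it bears only loosely on this change. More relevant is compound 3, which also carries a sulfamoyl group and gives 8910 nM, though on a quite different chain. On these data alone, neither observation points to a large shift in this assay, so no step beyond the scatter is expected, and the direction remains open. The estimated change is a 1.2-fold lower number from compound 2 to compound 4 (0.08 log units; within the scatter). With so little direct evidence, the range must stay wide. For compound 4 the expected value is 6000 nM, with an estimated range from 1500 nM to 20000 nM.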

Compound 4, half-maximal inhibitory concentration: 1610000 nM
For compound 4 the middle estimate is 270-fold (2.43 log units) below the measured one; the measured number lies above the stated range.
By their numbers in this assay, from the lowest: compounds 1, 2 and 3 (each within the scatter of the next); then compound 4.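

In this assay there is a 230-fold higher number from compound 2 to compound 4 (2.35 log units; beyond the scatter) when sulfamoyl replaces hydroxy on the aromatic carbon para to a large group. This position therefore does not tolerate every group, and the choice of group here can move the number far beyond the scatter. Going by these compounds alone, the earlier compounds could not show this, as their one step gave only a 1.4-fold higher number from compound 1 to compound 2 (0.13 log units; within the scatter) for hydrogen in place of methyl at a different place. No measurement shown here accounts for the size of this step.

On these data alone, it remains open whether replacing hydroxy with almost any other group gives a weaker inhibitor, or whether the large step is particular to sulfamoyl. An amine or a carboxylic acid at this same place could separate those two possibilities.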